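The compounds below may be only part of what the source reports. "The series", "measured", "known", "first", "only" and "open" are said of these compounds alone.

Of the three compounds measured, compound 1 `CCN(CC)CCN(C)Cc1c(C(C)(C)C)nc2n(Cc3ccccc3F)c(C)c(-c3cccc(OC)c3)c(=O)n12` gives 260 nM in an assay on isolated protein for binding affinity to Gonadotropin-releasing hormone receptor (Homo sapiens); a lower number here means a stronger inhibitor, a higher number a weaker inhibitor. Compound 2 `COC(=O)C(C)(C)c1nc2n(Cc3ccccc3F)c(C)c(-c3cccc(OC)c3)c(=O)n2c1CN(C)Cc1ccccc1O` gives 490 nM, which lies within the usual scatter of that figure, while compound 3 `COC(=O)C(C)(C)c1nc2n(Cc3ccccc3F)c(C)c(-c3cccc(OC)c3)c(=O)n2c1CN1CCC(c2ccccc2)CC1` gives 5100 nM and is clearly weaker than both. For the measured compounds named here, the one step that changes only the amine on the saturated chain carbon bound to an aromatic carbon is a 10-fold higher number from compound 2 to compound 3 (1.02 log units; beyond the scatter), a large weakening. Compound 4 `COc1cccc(-c2c(C)n(Cc3ccccc3F)c3nc(C(C)(C)C)c(CNCC4CCCCC4)n3c2=O)c1` differs from compound 1 in that same place: (cyclohexylmethyl)amino in place of (2-(diethylamino)ethyl)(methyl)amino on a saturated chain carbon bound to an aromatic carbon. That single comparable step was large and weakening, but compounds 2 and 3 differ from compound 1 elsewhere as well, so the guide is loose. Compound 4 is therefore expected to bind somewhat more weakly, by a 2.1-fold higher number from compound 1 to compound 4 (0.33 log units; beyond the scatter), giving an estimated 550 nM, likely between 150 nM and 2000 nM.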

Compound 4, inhibition constant: 430 nM
Compound 4: the middle estimate sits 1.3-fold (0.11 log units) above what was measured, and the stated range covers the measured number.
By their numbers in this assay, from the lowest: compounds 1, 4 and 2 (each within the scatter of the next); then compound 3.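

In this assay the change of (2-(diethylamino)ethyl)(methyl)amino to (cyclohexylmethyl)amino gives a 1.7-fold higher number from compound 1 to compound 4 (0.22 log units; within the scatter) and stays within the scatter, so the two compounds cannot be told apart. This place on a saturated chain carbon bound to an aromatic carbon therefore accepts a six-membered carbon ring and a hydrogen-bond donor without a clear loss, unlike the large step seen with 4-phenylpiperidin-1-yl in the compound 2 series. No measurement at hand explains this result. As far as these compounds go, how a carboxylic acid or a plain primary amine would fare at this place remains open.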